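A few compounds are considered here, and "the series" means these few. Any claim that something is new, unique, unknown or untested is made for them only; others in the source may bear on it.

In a functional assay on CCRF-CEM cells (Homo sapiens) for inhibition, read by cell counting, with a stated time of 72 h (a lower number here means a stronger inhibitor, a higher number a weaker inhibitor), three compounds sharing one core have been measured: compound 1 `CCN(CC)CN1C(=O)/C(=N/NC(=S)Nc2ccc(Cl)cc2)c2ccccc21` gives 10000 nM, compound 2 `CCN(CC)CN1C(=O)/C(=N/NC(=S)Nc2ccccc2)c2ccccc21` gives 11000 nM, and compound 3 `CCN(CC)CN1C(=O)/C(=N/NC(=S)Nc2ccc(C)cc2)c2ccccc21` gives 12000 nM. Compound 3 therefore stands level with the other two, as its differences from both lie within the scatter.

Compound 4 `CCN(CC)CN1C(=O)/C(=N/NC(=S)Nc2ccc(C)cc2)c2cc(Cl)ccc21` differs from compound 3 by chloro in place of hydrogen on an aromatic carbon, on a ring that is part of a fused system of two rings.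

The closest evidence comes from changes on the other aromatic ring, outside that fused system. There, a 1.1-fold higher number from compound 1 to compound 2 (0.04 log units; within the scatter) for hydrogen in place of chloro, a 1.2-fold higher number from compound 1 to compound 3 (0.08 log units; within the scatter) for methyl in place of chloro, and a 1.1-fold higher number from compound 2 to compound 3 (0.04 log units; within the scatter) for methyl in place of hydrogen, all within the scatter. For the measured compounds named here, no measured compound carries a new group on the fused system, so this guide is indirect and the range must stay wide.

Going by the values given here, the expected change is a 1.3-fold lower number from compound 3 to compound 4 (0.12 log units; within the scatter), with no step expected beyond the scatter. For compound 4 the estimated value is 9000 nM, within an expected range from 4000 nM to 18000 nM.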

Compound 4, half-maximal inhibitory concentration: 4600 nM
For compound 4 the middle estimate is 2.0-fold (0.29 log units) above the measured one; the range from low to high includes it.
By their numbers in this assay, from the lowest: compound 4; then compounds 1, 2 and 3 (each within the scatter of the next).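

In this assay, chloro in place of hydrogen on the ring that is part of the fused system gives the only step among these compounds that lies beyond the scatter: a 2.6-fold lower number from compound 3 to compound 4 (0.42 log units; beyond the scatter). The earlier changes, all on the other aromatic ring, left compound 1, compound 2 and compound 3 level, so this position is the first shown where a substituent change moves the number measurably, though only modestly. This does not prove that chloro matters more here than on the other ring, as the two comparable steps do not differ beyond the scatter: the same change on two cores in this assay, a 1.1-fold higher number (0.04 log units; within the scatter) from compound 1 to compound 2 and a 2.6-fold higher number (0.42 log units; beyond the scatter) from compound 4 to compound 3, 2.4-fold (0.38 log units) apart, within the scatter of two such steps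

From the compounds shown here alone, whether a methyl group, a methoxy group or an amine at this position would act as chloro does remains open. Also open, going by these compounds, is whether chloro here would give a similar step with the chloro or unsubstituted ring of compound 1 or compound 2.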